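This account rests on a few compounds, and the source may have more. Where it says the series, first, only, none or still open, it means among the compounds named here.

Compound 1 `COc1cc2ncnc(Nc3cccc(Br)c3)c2cc1OCCCCC(=O)Nc1ccc(S(N)(=O)=O)cc1`: 14900 nM
Compound 2 `COc1cc2ncnc(Nc3cccc(Cl)c3)c2cc1OCCCCC(=O)Nc1ccc(S(N)(=O)=O)cc1`: 11200 nM
Compound 3 `COc1cc2ncnc(Nc3ccc(Br)cc3)c2cc1OCCCCC(=O)Nc1ccc(S(N)(=O)=O)cc1`: > 40000 nM

Of the compounds shown here, three sharing one core have been tested in a functional assay on A549 cells (Homo sapiens) for antiproliferative activity, read by MTT assay, with a stated time of 72 h; on this read-out lower numbers stand for stronger inhibition and higher numbers for weaker inhibition. Compound 1 gives 14900 nM, the higher of the two real numbers, though its nearest neighbour is close: the change of a 1.3-fold lower number from compound 1 to compound 2 (0.12 log units; within the scatter) stays within the scatter, so the two cannot be ranked. For compound 3 the result is only a limit of the assay, > 40000 nM, as noted in the limit of > 40000 nM in this assay, at which 1 of the 3 values shown sits. Moving the halogen gave an at least 2.6-fold higher number from compound 1 to compound 3 (0.42 log units; beyond the scatter) and an at least 3.5-fold higher number from compound 2 to compound 3 (0.55 log units; beyond the scatter).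

Compound 4 `COc1cc2ncnc(Nc3cccc(C)c3)c2cc1OCCCCC(=O)Nc1ccc(S(N)(=O)=O)cc1` is not yet measured. It differs from compound 1 by methyl in place of bromo on an aromatic carbon. Within the data shown here, no measured step swaps the bromo for a carbon group, so the closest guide is the step in which the bromo at the same place became chloro, a 1.3-fold lower number from compound 1 to compound 2 (0.12 log units; within the scatter), which stayed within the scatter. The other two steps concern where the group sits, not what it is, and the group here stays in place. The expectation for this assay is therefore no step beyond the scatter, in either direction.

On that basis compound 4 is estimated at 15000 nM, with a range from 6000 nM to 38000 nM. This estimate means an expected change of a 1.0-fold higher number from compound 1 to compound 4 (0.00 log units; within the scatter).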

Compound 4, half-maximal inhibitory concentration: 16000 nM
Compound 4: the middle estimate sits 1.1-fold (0.03 log units) below what was measured; low and high end bracket the measured number.
By their numbers in this assay, from the lowest: compounds 2, 1 and 4 (each within the scatter of the next). At a limit, above all of these: compound 3.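

In this assay, the earlier compounds had only shown one halogen replacing another at this place, on an aromatic carbon meta to a large group, whereas methyl is a carbon group and still leaves the result within the scatter: a 1.1-fold higher number from compound 1 to compound 4 (0.03 log units; within the scatter), and a 1.4-fold higher number from compound 2 to compound 4 (0.15 log units; within the scatter). Among compounds 1, 2 and 4, then, neither bromo, chloro nor methyl can be ranked against the others, so a halogen is not needed here for a number of this size. The step to the remaining compound lies beyond the scatter, an at least 2.5-fold lower number from compound 3 to compound 4 (0.39 log units; beyond the scatter), but it changes both the group and its place, so it cannot be assigned to either change alone. The result for compound 3 is a limit and not a number: the limit of > 40000 nM in this assay, at which 1 of the 4 values shown sits.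

From the compounds shown here alone, all three groups that can be compared at this place are small and have no hydrogen-bond donors or acceptors, so it remains open whether an amine or a carboxylic acid would be tolerated there. Going by these compounds, the effect of a longer or shorter chain in place of the one leading to the amide also remains open.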